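A few compounds are considered here, and "the series" means these few. Any claim that something is new, unique, unknown or untested is made for them only; others in the source may bear on it.

Measured in an ADME assay on microsomes from liver (Homo sapiens) for metabolic stability, read by LC-MS, tested at 1 uM; on this read-out higher numbers stand for fast clearance and lower numbers for slow clearance:
- compound 1 `O=S(=O)(c1ccc([C@H]2CC[C@]3(CC2)OOC2(O3)C3CC4CC(C3)CC2C4)cc1)N1CCNCC1`: 16 mL.min-1.g-1
- compound 2 `NCCOc1ccc([C@H]2CC[C@]3(CC2)OOC2(O3)C3CC4CC(C3)CC2C4)cc1`: < 7 mL.min-1.g-1 (a limit of the assay, not a number)

Compound 2 stands at the limit of < 7 mL.min-1.g-1 in this assay, at which 1 of the 2 values shown sits, so only a limit is known for it.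

Compound 3 `OC1(COc2ccc([C@H]3CC[C@]4(CC3)OOC3(O4)C4CC5CC(C4)CC3C5)cc2)CCNCC1` comes next. The change from compound 2 is 4-hydroxypiperidin-4-yl in place of aminomethyl on a saturated chain carbon bound to an oxygen on an aromatic ring. Cut one bond further out, this reads 2-aminoethoxy to (4-hydroxypiperidin-4-yl)methoxy.

Among the measured compounds shown here, only one measured step bears on this, and only loosely. A different swap on an aromatic carbon, 2-aminoethoxy in place of (piperazin-1-yl)sulfonyl, gave an at least 2.2-fold lower number from compound 1 to compound 2 (0.35 log units; beyond the scatter). With the oxygen on an aromatic ring kept, compound 3 is expected to stay closer to compound 2 than to compound 1 at 16 mL.min-1.g-1.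

For the measured compounds named here, no step clearly beyond the scatter is expected in this assay, and any drift would more likely be upward, the estimated change being an at least 1.1-fold higher number from compound 2 to compound 3 (0.05 log units; that floor lies within the scatter). A report of a limit alone would not be surprising. For compound 3 the expected value is 8 mL.min-1.g-1, with an estimated range from 5 mL.min-1.g-1 to 18 mL.min-1.g-1.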

Compound 3, intrinsic clearance in microsomes: 16 mL.min-1.g-1
Compound 3: the middle estimate sits 2.0-fold (0.30 log units) below what was measured, within the range that was stated.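

In this assay, 4-hydroxypiperidin-4-yl in place of aminomethyl on a saturated chain carbon bound to an oxygen on an aromatic ring gives a clear step (an at least 2.2-fold higher number from compound 2 to compound 3 (0.35 log units; beyond the scatter)), so the read-out depends on what stands at this chain carbon even with the oxygen on the aromatic ring kept. The low reading seen with 2-aminoethoxy therefore does not carry over to every group attached through that oxygen: (4-hydroxypiperidin-4-yl)methoxy in place of (piperazin-1-yl)sulfonyl on an aromatic carbon gives no change at the digits printed from compound 1 to compound 3 (within the scatter). The size of the step into compound 3 is known only as a floor because compound 2 is held by a limit of the assay, not a number: the limit of < 7 mL.min-1.g-1 in this assay, at which 1 of the 3 values shown sits.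

The compounds shown leave open whether the step follows the piperidine ring, the hydroxyl or simply the larger group, since the change brings these in together. Piperidin-4-ylmethoxy, which lacks the hydroxyl, and 3-aminopropoxy, a longer chain with a primary amine, would help to separate these parts, and a number for compound 2 in place of its limit would fix the size of the step.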